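Notes on the fluoro-for-ethyl step in the series

The source may hold more compounds than are shown below. What is called first, only, known or untested is meant among the compounds shown, and "the series" means these compounds.

Of the compounds shown here, three have been measured in a functional assay on Hep 3B2 cells (Homo sapiens) for antiproliferative activity, read by MTT assay, with a stated time of 24 h, tested at 33.33 ug/mL; on this read-out lower numbers stand for a weaker effect and higher numbers for a stronger effect at the one concentration tested. Compound 1 `Cc1c(C(=O)Nc2c(F)cc(-c3cccc(F)c3)cc2F)nc2ccc(F)cc2c1O` gives 41.2%, compound 2 `Cc1ccc2nc(C(=O)Nc3c(F)cc(-c4cccc(F)c4)cc3F)c(C)c(C(=O)O)c2c1` gives 41.3%, and compound 3 `CCc1ccc2nc(C(=O)Nc3c(F)cc(-c4cccc(F)c4)cc3F)c(C)c(C(=O)O)c2c1` gives 36.3%. Compound 3 has the lowest of the three numbers, but its gaps to compound 1 and to compound 2 both lie within the scatter, so no order among the three can be read from these numbers.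

The next compound, compound 4 `Cc1c(C(=O)Nc2c(F)cc(-c3cccc(F)c3)cc2F)nc2ccc(F)cc2c1C(=O)O`, differs from compound 3 in one place: fluoro in place of ethyl on an aromatic carbon.

Among the compounds with values here, only one measured step exists within the set, a number 5 percentage points lower from compound 2 to compound 3 (within the scatter). It concerns the same part of the ring system but a different change, methyl in place of hydrogen on a saturated chain carbon bound to an aromatic carbon, and it stayed within the scatter. Within the data shown here, no measured pair shows fluoro against ethyl directly. Compound 1 carries fluoro at a ring position with a different group elsewhere, and its value sits close to that of compound 3.

Given these small movements, compound 4 is expected to move by a number 3.7 percentage points higher from compound 3 to compound 4 (within the scatter) in this assay, a step not beyond the scatter. Compound 4 is therefore estimated at 40%, with a range from 28% to 52%.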

Compound 4, a percentage reported as inhibition, at one concentration (the size of the read-out at that concentration, not a potency): 34.3%
Beside the measured number, compound 4's estimate is 5.7 percentage points above it; measured number inside the range.
By their numbers in this assay, from the lowest: compounds 4, 3, 1 and 2 (each within the scatter of the next).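

In this assay, fluoro in place of ethyl on this aromatic carbon gives a number 2 percentage points lower from compound 3 to compound 4 (within the scatter) and fluoro in place of methyl on the same carbon gives a number 7 percentage points lower from compound 2 to compound 4 (within the scatter) in the same series, so ethyl, methyl and fluoro here lie within the scatter of one another. Within the data shown here, with fluoro held at this place, carboxy in place of hydroxy on an aromatic carbon gives a number 6.9 percentage points lower from compound 1 to compound 4 (within the scatter) and thus supplies the first one-place comparison for compound 1, which also stays within the scatter. No independent measurement bears on any of these steps.

Going by these compounds, every step among the four compounds lies within the scatter at the one concentration tested, so it remains open whether any group on the carbon that carries fluoro in compound 4, such as an amine, a methoxy group or a longer chain like propyl, would give a step beyond it. On these data alone, it also remains open whether a methyl ester or a primary amide on the carbon that carries carboxy in compound 4 would give a step beyond the scatter.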